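The compounds below may be only part of what the source reports. "The series", "measured", "known", "first", "only" and "open" are said of these compounds alone.

Working notes on the series, read in an ADME assay on the whole organism (strain FVB) for pharmacokinetics, with Mus musculus as the target, read by LC-MS, at a dose of 30 mg/kg by the oral route; a higher number here means more compound in the circulation at the dose given, a lower number less compound in the circulation. Compound 1 `NCCOc1ccc([C@H]2CC[C@]3(CC2)OOC2(O3)C3CC4CC(C3)CC2C4)cc1` gives 287 nM. Compound 2 `c1cc([C@H]2CC[C@]3(CC2)OOC2(O3)C3CC4CC(C3)CC2C4)ccc1OC1CCNCC1` gives 810 nM. Compound 3 `CC(C)(CN)Oc1ccc([C@H]2CC[C@]3(CC2)OOC2(O3)C3CC4CC(C3)CC2C4)cc1` gives 529 nM. Compound 2 is separated from compound 1 only, with a 2.8-fold higher number from compound 1 to compound 2 (0.45 log units; beyond the scatter). Against compound 3 no order holds, with a 1.5-fold lower number from compound 2 to compound 3 (0.19 log units; within the scatter). The remaining pair also stays together, with a 1.8-fold higher number from compound 1 to compound 3 (0.27 log units; within the scatter).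

Compound 4 `CC1(C)CC(O)(COc2ccc([C@H]3CC[C@]4(CC3)OOC3(O4)C4CC5CC(C4)CC3C5)cc2)CC(C)(C)N1` keeps the core of compound 2 and changes the group on an oxygen on an aromatic ring: (4-hydroxy-2,2,6,6-tetramethylpiperidin-4-yl)methyl in place of piperidin-4-yl on an oxygen on an aromatic ring. All three measured steps swap the group at this same place, so all bear on the change, though only loosely. Among the compounds with values here, no measured compound carries a group like the entering one, and the data lack any direct precedent for it. Within the data shown here, the largest swap seen so far is the modest 2.8-fold higher number from compound 1 to compound 2 (0.45 log units; beyond the scatter), which gives the only guide to size. On that basis, no step beyond the scatter is expected in this assay, with only a slight lean towards a lower number. The expected step is a 1.4-fold lower number from compound 2 to compound 4 (0.13 log units; within the scatter). For compound 4 the estimate is 600 nM, with an expected range of 220 nM to 1700 nM.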

Compound 4, maximal plasma concentration: 1000 nM
Compound 4: middle estimate off by 1.7-fold (0.22 log units), on the low side; the range from low to high includes it.
By their numbers in this assay, from the lowest: compounds 1, 3, 2 and 4 (each within the scatter of the next, the first and the last beyond it).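

The group on an oxygen on an aromatic ring can grow from piperidin-4-yl to (4-hydroxy-2,2,6,6-tetramethylpiperidin-4-yl)methyl without a separable shift in this assay, as shown by a 1.2-fold higher number from compound 2 to compound 4 (0.09 log units; within the scatter). The new group also stays unresolved from the open-chain 1-(aminomethyl)-1-methylethyl group, with a 1.9-fold higher number from compound 3 to compound 4 (0.28 log units; within the scatter), yet it stands clear of the 2-aminoethyl compound, with a 3.5-fold higher number from compound 1 to compound 4 (0.54 log units; beyond the scatter), so compound 4 joins compound 2 as separated from compound 1, while compound 3 is not. No supporting data bear on why these numbers fall as they do.

As far as these compounds go, the hydroxy group and the 2,2,6,6-tetramethyl substitution enter together, so the contribution of each remains open, and a plain 4-hydroxypiperidin-4-ylmethyl or 2,2,6,6-tetramethylpiperidin-4-yl group would separate them. From the compounds shown here alone, whether the amine itself is needed at this position also remains open, as every group here carries one, and an amide, a carboxylic acid or a simple ether chain in its place would test that.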